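Chloro for amino on a purine core: expected gain

The source may hold more compounds than are shown below. What is called first, only, known or untested is meant among the compounds shown, and "the series" means these compounds.

Measured compounds:
compound 1 `ClCc1ccc(Cn2cnc3c(Cl)ncnc32)cc1`: 20900 nM
compound 2 `Nc1nc(Cl)c2ncn(Cc3ccccc3CCl)c2n1`: 26300 nM
compound 3 `ClCc1ccccc1Cn1cnc2nc(Cl)nc(Cl)c21`: 2180 nM

In a functional assay on SK-MEL-5 cells (Homo sapiens) for cytotoxicity, read by sulforhodamine B assay, with a stated time of 48 h (a higher number here means a weaker inhibitor of growth, a lower number a stronger inhibitor of growth), compound 2 gives the highest of the three numbers. Compound 1 sits within the scatter of it, so the two cannot be ordered. Compound 3, which carries two chloro groups on the core and no amino group, gives a lower number than compound 2, a gap well beyond the scatter.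

Compound 4 `ClCc1ccccc1Cn1cnc2c(Cl)nc(Cl)nc21` has not yet been measured. Its difference from compound 2 is chloro in place of amino on an aromatic carbon. With that change compound 4 also ends up with two chloro groups on the core and no amino group, which is the pattern seen in compound 3, the lowest number among the measured set.

A step down in number, beyond the scatter, is therefore expected from compound 2 to compound 4 in this assay, on the order of a 5.8-fold lower number from compound 2 to compound 4 (0.77 log units; beyond the scatter). Compound 4 is expected to give about 4500 nM, within a range of 1200 nM to 18000 nM.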

Compound 4, concentration for total growth inhibition: 1540 nM
Beside the measured number, compound 4's estimate is 2.9-fold (0.47 log units) above it; low and high end bracket the measured number.
By their numbers in this assay, from the lowest: compounds 4 and 3 (each within the scatter of the next); then compounds 1 and 2 (each within the scatter of the next).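

For the compounds shown here, compound 2 and compound 4 differ in one place only, which no pair among the earlier compounds did, so this change can now be read by itself. Amino leaves and chloro enters on an aromatic carbon between two ring nitrogen atoms, and in this assay this single change gives a 17-fold lower number from compound 2 to compound 4 (1.23 log units; beyond the scatter) as a large step. Going by these compounds alone, the group at this position therefore matters for growth inhibition in these cells, at least for this pair, and the earlier compounds could only hint at that.

On these data alone, whether a different group here, such as methoxy or dimethylamino, would give a number like that of chloro or of amino remains open. Nothing at hand explains why this change gives so large a step.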